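Indolyl vinyl sulfone series: phenyl methoxy removal

The compounds below may be only part of what the source reports. "The series", "measured", "known", "first", "only" and "open" are said of these compounds alone.

Two compounds of the series have numbers. Compound 1 `COc1ccc(-c2[nH]c3ccccc3c2/C=C(\C#N)S(=O)(=O)c2ccccc2)cc1` carries a 4-methoxyphenyl on the shared core; in a functional assay on HCT-116 cells (Homo sapiens) for inhibition, read by sulforhodamine B assay, with a stated time of 48 h (a higher number here means a weaker inhibitor of growth, a lower number a stronger inhibitor of growth), compound 1 gives 399 nM. Compound 2 `COc1ccc(-c2[nH]c3ccc(OC)cc3c2/C=C(\C#N)S(=O)(=O)c2ccccc2)cc1` adds a methoxy on the core itself, and in this assay compound 2 gives 539 nM. Within the data shown here, the two numbers lie within the scatter of each other: the step of a 1.4-fold higher number from compound 1 to compound 2 (0.13 log units; within the scatter) is the only measured step so far, and it does not separate the pair.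

Compound 3 `COc1ccc2[nH]c(-c3ccccc3)c(/C=C(\C#N)S(=O)(=O)c3ccccc3)c2c1` is compound 2 with the change (hydrogen in place of methoxy on an aromatic carbon), so the 4-methoxyphenyl of compound 2 becomes a plain phenyl while the methoxy on the core stays. Among the measured compounds shown here, no measured step touches this phenyl ring; the single measured step, from compound 1 to compound 2, concerns a methoxy on a different ring and was within the scatter. With only that to go on, the expectation for this assay is a step of no more than the scatter, in no definite direction.

Compound 3 is therefore expected at about 520 nM, with a range of 200 nM to 1400 nM. The step from compound 2 implied by this expectation is a 1.0-fold lower number from compound 2 to compound 3 (0.02 log units; within the scatter).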

Compound 3, concentration for 50% growth inhibition: 3700 nM
The estimate for compound 3 lay 7.1-fold (0.85 log units) below the measured number; measured number outside the range, above it.
By their numbers in this assay, from the lowest: compounds 1 and 2 (each within the scatter of the next); then compound 3.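

In this assay, among these compounds, going from 4-methoxyphenyl to phenyl gives a 6.9-fold higher number from compound 2 to compound 3 (0.84 log units; beyond the scatter), the first step beyond the scatter. This position, para to a large group, therefore responds to the loss of its methoxy, whereas the methoxy on the core gave only a 1.4-fold higher number from compound 1 to compound 2 (0.13 log units; within the scatter) and did not separate its pair. The reading rests on this one step, taken with the core methoxy in place, and nothing available here accounts for its size.

Open, going by these compounds, is whether the lower number of compound 2 belongs to methoxy itself or would also come with another group at this position, such as a hydroxyl, an ethoxy, a fluorine or an amine. Also open, on these data alone, is whether the methoxy on the core has so little effect when the ring carries no methoxy, or whether the step seen here would change in size with the core left unsubstituted, a question that the pair formed by compound 1 and compound 2 cannot settle.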